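Three Limit-Bound Thiophenes and a Methoxy Replacement

The compounds below may be only part of what the source reports. "The series", "measured", "known", "first", "only" and "open" are said of these compounds alone.

Compound 1, `CC(=O)c1ccc(-c2sc(N)c(C(=O)c3ccccc3)c2-c2cccc(C(F)(F)F)c2)cc1`: in a functional assay on CHO-K1 cells for agonist activity at adenosine receptor A1 (Homo sapiens), read by GTPgammaS binding (a lower number here means that less compound is needed, a higher number that more compound is needed for the effect), compound 1 gives > 10 uM, a limit of the assay.
Compound 2, `CCOC(=O)c1c(N)sc(-c2ccccc2)c1-c1cccc(C(F)(F)F)c1`: compound 2 gives > 10 uM, again a limit.
Compound 3, `CCOC(=O)c1c(N)sc(-c2ccc(C(C)=O)cc2)c1-c1cccc(C(F)(F)F)c1`: compound 3 gives > 10 uM, also a limit.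

Compound 3 thus stands at the limit of > 10 uM in this assay, at which 3 of the 3 values shown sit. Both measured steps reach it from compounds that themselves sit at that limit: a step that the two limits leave unreadable from compound 1 to compound 3 and a step that the two limits leave unreadable from compound 2 to compound 3, neither readable in size. Compound 4, `CCOC(=O)c1c(N)sc(-c2ccc(OC)cc2)c1-c1cccc(C(F)(F)F)c1`, differs from compound 3 by methoxy in place of acetyl on an aromatic carbon. No measured step bears on this change, so no direction can be read from the numbers shown. Compound 4 is expected to stay near the limit because the limit of > 10 uM in this assay, at which 3 of the 3 values shown sit, is where compound 3 and both of its neighbours sit, giving an expected step that the limit leaves unreadable from compound 3 to compound 4. Compound 4 is therefore estimated at 20 uM, between 5 uM and 80 uM.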

Compound 4, concentration for half-maximal effect: > 10 uM
Compound 4: only a limit was reported; the forecaster's own chance of this, stated with the estimate: 80%; the middle value does not contradict the limit.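

Compound 4 is also reported only as a limit, so the steps to it from compound 2 and compound 3 cannot be read in size: the limit of > 10 uM in this assay, at which 4 of the 4 values shown sit.

The compounds shown leave open whether any change to the shared core gives a readable value in this assay.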